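The source may report more compounds than this note shows. Statements on the series, on what has been measured and on what is new or still open speak of the compounds shown alone.

Compound 1 `COc1cc(NC(=O)c2cnccn2)c2ncccc2c1`: 470 nM
Compound 2 `COc1cc(NC(=O)c2ncccn2)c2ncccc2c1`: 1300 nM

In a functional assay on MIA PaCa-2 cells (Homo sapiens) for inhibition, read by MTT assay, with a stated time of 72 h (on this read-out higher numbers stand for weaker inhibition and lower numbers for stronger inhibition), compound 2 gives 1300 nM, the highest of the two numbers; the nearest is compound 1 with 470 nM, and a 2.8-fold higher number from compound 1 to compound 2 (0.44 log units; beyond the scatter). Compound 3 `O=C(Nc1cc(OCCC2CCNCC2)cc2cccnc12)c1ncccn1` differs from compound 2 by (piperidin-4-yl)methyl in place of hydrogen on a saturated chain carbon bound to an oxygen on an aromatic ring. Within the data shown here, the only measured step alters the group on the carbonyl carbon, not the chain carbon bound to the ring oxygen, so no measured step bears on this change. For compound 3 the expected step is no change at the digits printed from compound 2 to compound 3 (within the scatter), within the scatter. Compound 3 is estimated at 1300 nM, ranging from 300 nM to 5000 nM.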

Compound 3, half-maximal inhibitory concentration: > 10000 nM
Compound 3: a limit, no number; the forecaster's own chance of this, stated with the estimate: 5%; at least 7.6-fold (0.88 log units) between middle value and limit.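

Among these compounds, the earlier compounds varied only the group on the carbonyl carbon, so this is the first view of a change at the methoxy group. Replacing methoxy with 2-(piperidin-4-yl)ethoxy brings an at least 7.6-fold higher number from compound 2 to compound 3 (0.88 log units; beyond the scatter) and so weakens inhibition in these cells. The value of compound 3 is a limit of the assay and not a number: the limit of > 10000 nM in this assay, at which 1 of the 3 values shown sits.

Still open, as far as these compounds go, is whether the chain or the piperidin-4-yl group matters more, which a plain butoxy chain or a 2-aminoethoxy group would help separate. Also open, from the compounds shown here alone, is whether 2-(piperidin-4-yl)ethoxy has the same effect with pyrazin-2-yl on the carbonyl carbon.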